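Benzothiazolyl anilides: a chloropyridine isomer swap

This account rests on a few compounds, and the source may have more. Where it says the series, first, only, none or still open, it means among the compounds named here.

Measured in an ADME assay on Raji cells (Homo sapiens) for inhibition, with a stated time of 72 h; a higher number here means that more compound is needed for the effect, a lower number that less compound is needed:
compound 1 `CC(Cl)C(=O)Nc1cccc(-c2nc3ccccc3s2)c1` gives > 25000 nM;
compound 2 `CC(C)(CCl)C(=O)Nc1cccc(-c2nc3ccccc3s2)c1` gives > 25000 nM;
compound 3 `O=C(Nc1cccc(-c2nc3ccccc3s2)c1)c1ccnc(Cl)c1` gives > 25000 nM.

Every value shown is a limit of this assay, not a number. Compound 3 sits at that limit, and the limit of > 25000 nM in this assay, at which 3 of the 3 values shown sit, holds all three measured compounds together, so nothing sets compound 3 apart from the others. Compound 4 `O=C(Nc1cccc(-c2nc3ccccc3s2)c1)c1ccncc1Cl` differs from compound 3 by 3-chloropyridin-4-yl in place of 2-chloropyridin-4-yl on a carbonyl carbon. Going by the values given here, the measured steps a step that the two limits leave unreadable from compound 1 to compound 2, a step that the two limits leave unreadable from compound 1 to compound 3 and a step that the two limits leave unreadable from compound 2 to compound 3 all run between limits and give no readable size, and none of them moves the chlorine within the pyridine, so no step bears directly on this change. For compound 4 the step that the limit leaves unreadable from compound 3 to compound 4 is therefore expected to be none beyond the scatter. Compound 4 is estimated at 30000 nM, in the range 10000 nM to 100000 nM, most likely again reported only as a limit.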

Compound 4, half-maximal effective concentration: > 25000 nM
Compound 4 gave a limit, no number (the forecaster's own chance of this, stated with the estimate: 85%); the middle value does not contradict the limit.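

Compound 3 and compound 4 both stand only as limits in this assay, as do compound 1 and compound 2, so no step among them can be read: the limit of > 25000 nM in this assay, at which 4 of the 4 values shown sit.

The compounds shown leave open whether 3-chloropyridin-4-yl and 2-chloropyridin-4-yl differ at all in this read-out.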